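Chloro to bromo on the aryl halide: working notes

The compounds below may be only part of what the source reports. "The series", "measured", "known", "first", "only" and "open" are said of these compounds alone.

Measured so far:
- compound 1 `CC1=C(/C=C/C(=O)/C=C/c2ccccc2)C(C)(C)CCC1`: 12400 nM in a functional assay on PC-3 cells (Homo sapiens) for cytotoxicity, read by sulforhodamine B assay, with a stated time of 48 h; on this read-out lower numbers stand for stronger inhibition and higher numbers for weaker inhibition
- compound 2 `CC1=C(/C=C/C(=O)/C=C/c2ccc(Cl)cc2)C(C)(C)CCC1`: 9500 nM in this assay

Among the measured compounds shown here, compound 2 carries the lower of the two numbers, but the only step, a 1.3-fold lower number from compound 1 to compound 2 (0.12 log units; within the scatter), lies within the scatter, so no order between the two is claimed. Compound 3 `CC1=C(/C=C/C(=O)/C=C/c2ccc(Br)cc2)C(C)(C)CCC1` differs from compound 2 by bromo in place of chloro on an aromatic carbon. For the measured compounds named here, the one step that bears on this exchange is a 1.3-fold lower number from compound 1 to compound 2 (0.12 log units; within the scatter), small and within the scatter, and a swap of one halogen for another gives no basis for a larger move in this assay. The estimated step is a 1.2-fold lower number from compound 2 to compound 3 (0.07 log units; within the scatter). Compound 3 is expected at 8000 nM, range 4000 nM to 16000 nM.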

Compound 3, half-maximal inhibitory concentration: 18900 nM
Compound 3: middle estimate off by 2.4-fold (0.37 log units), on the low side; the measured number lies above the stated range.
By their numbers in this assay, from the lowest: compounds 2, 1 and 3 (each within the scatter of the next).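

Bromo in place of chloro gives a 2.0-fold higher number from compound 2 to compound 3 (0.30 log units; within the scatter) in this assay and bromo in place of hydrogen gives a 1.5-fold higher number from compound 1 to compound 3 (0.18 log units; within the scatter) on the same aromatic carbon. Hydrogen, chloro and bromo at this position therefore stand within the scatter of one another, and no order among them can be claimed. Nothing at hand explains these numbers.

Still open, as far as these compounds go, is whether a group of another kind here, such as an amine, a carboxylic acid or a methoxy group, would move the number beyond the scatter. Also open, from the compounds shown here alone, is whether any change to the shared core would do so.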